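Isopropyl for isobutyl on the imine nitrogen of compound 1

The source may hold more compounds than are shown below. What is called first, only, known or untested is meant among the compounds shown, and "the series" means these compounds.

Going by the values given here, compound 1 `CC(C)C/N=c1\c(O)c(O)\c1=N/Cc1ccc(C#N)cc1` is the weakest of the three measured members: in a functional assay for inhibition, with Rattus norvegicus as the target (a higher number here means a weaker inhibitor, a lower number a stronger inhibitor), compound 1 gives 10200 nM. Compound 2 `CCC(C)(C)/N=c1\c(O)c(O)\c1=N/Cc1ccc(F)c(F)c1` gives 1600 nM in this assay, and compound 3 `CC(C)(C)/N=c1\c(O)c(O)\c1=N/Cc1ccc(C#N)cc1Cl` gives 140 nM; both gaps to compound 1 lie beyond the scatter. Compound 4 `CC(C)/N=c1\c(O)c(O)\c1=N/Cc1ccc(C#N)cc1` differs from compound 1 in one place only: isopropyl in place of isobutyl on a double-bonded nitrogen. Among the compounds with values here, no measured pair isolates this alkyl change; compound 2 and compound 3 carry different aryl substituents as well as different alkyl groups, so their values cannot be read as a step for the nitrogen substituent alone. A small gain is expected, a 1.7-fold lower number from compound 1 to compound 4 (0.23 log units; within the scatter), possibly not beyond the scatter. Compound 4 is therefore estimated at 6000 nM in this assay, within 1500 nM to 20000 nM.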

Compound 4, half-maximal inhibitory concentration: 14000 nM
For compound 4 the middle estimate is 2.3-fold (0.37 log units) below the measured one, and the stated range covers the measured number.
By their numbers in this assay, from the lowest: compound 3; then compound 2; then compounds 1 and 4 (each within the scatter of the next).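

Going by these compounds alone, the step of a 1.4-fold higher number from compound 1 to compound 4 (0.14 log units; within the scatter) in this assay is the first one that isolates this nitrogen substituent, and it shows that isopropyl and isobutyl cannot be told apart here with the rest of compound 1 held fixed. At this position, then, the change of one carbon and of branching between these two groups has no resolved effect on the read-out. Nothing available ties this result to any property of either group.

Still open, on these data alone, is whether a cyclohexyl group or a longer chain such as n-hexyl on this nitrogen would move the number beyond the scatter. How much of the lower numbers of compound 2 and compound 3 belongs to the alkyl group, and how much to the aryl substituents, also remains unresolved.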